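The source may report more compounds than this note shows. Statements on the series, on what has been measured and on what is new or still open speak of the compounds shown alone.

Measured in a physicochemical assay for solubility, read by LC-MS, using the shake flask method, measured as thermodynamic solubility, with a stated time of 24 h, at pH 6.5; a lower number here means a less soluble compound, a higher number a more soluble compound:

- Compound 1 `O=C(O)c1ccc(-n2cc(CO[C@H]3O[C@H](CO)[C@@H](O)[C@H](O)[C@@H]3O)nn2)cc1` gives > 3000 ug/mL (a limit)
- Compound 2 `O=C(O)c1cncc(-n2cc(CO[C@H]3O[C@H](CO)[C@@H](O)[C@H](O)[C@@H]3O)nn2)c1` gives > 3000 ug/mL (a limit)
- Compound 3 `OC[C@H]1O[C@H](OCc2cn(-c3cccc(F)c3)nn2)[C@@H](O)[C@@H](O)[C@@H]1O` gives > 3000 ug/mL (a limit)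

Compound 3 has no number, only the limit > 3000 ug/mL. The series as a whole stands at the limit of > 3000 ug/mL in this assay, at which 3 of the 3 values shown sit. Compound 4 `COc1ccc(-n2cc(CO[C@H]3O[C@H](CO)[C@@H](O)[C@H](O)[C@@H]3O)nn2)cc1` carries 4-methoxyphenyl in place of 3-fluorophenyl on an aromatic nitrogen. Two measured changes at this same place bear on it, a step that the two limits leave unreadable from compound 1 to compound 3 and a step that the two limits leave unreadable from compound 2 to compound 3, and neither has a readable size. No step beyond the scatter is therefore expected in this assay, and no direction can be given. The expected step is a number no higher from compound 3 to compound 4 (the limit leaves the size open). For compound 4 the estimate is 3000 ug/mL, with an expected range from 1000 ug/mL to 6000 ug/mL.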

Compound 4, solubility: 2600 ug/mL
Compound 4: the middle estimate sits 1.2-fold (0.06 log units) above what was measured; the measured number falls inside the stated range.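

In this assay, among these compounds, compound 4 gives 2600 ug/mL, the first number rather than a limit. Measured against the limits of the other compounds, the change gives an at least 1.1-fold lower number from compound 3 to compound 4 (0.06 log units; that floor lies within the scatter), an at least 1.1-fold lower number from compound 2 to compound 4 (0.06 log units; that floor lies within the scatter) and an at least 1.1-fold lower number from compound 1 to compound 4 (0.06 log units; that floor lies within the scatter), so no step beyond the scatter can be claimed for 4-methoxyphenyl at this place. The rest of the series stays at a limit: the limit of > 3000 ug/mL in this assay, at which 3 of the 4 values shown sit.

Going by these compounds, the steps among compound 1, compound 2 and compound 3 cannot be read, and how far those compounds lie past their limit remains open. Also open, on these data alone, is what an amine or a longer chain on the phenyl ring would give at this aromatic nitrogen.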